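The source may report more compounds than this note shows. Statements on the series, on what has been measured and on what is new or still open speak of the compounds shown alone.

In a functional assay on MCF7 cells (Homo sapiens) for antiproliferative activity, read by XTT assay, with a stated time of 72 h (on this read-out higher numbers stand for weaker inhibition and lower numbers for stronger inhibition), three compounds have been measured:
compound 1, `COc1ccc(-c2cc3ccccc3nc2/C=C/C(=O)c2ccccc2)cc1`, with 4040 nM;
compound 2, `COc1ccc(-c2cc3ccccc3nc2/C=C/C(=O)c2ccc(N)cc2)cc1`, with 6920 nM;
compound 3, `COc1ccc(-c2cc3ccccc3nc2/C=C/C(=O)c2cccs2)cc1`, with 1030 nM.

All three share one core and differ only in the group on the carbonyl carbon or on its ring. Compound 1 gives the second highest of these three numbers. Its number and that of compound 2, which carries an amino in place of hydrogen on an aromatic carbon, lie within the scatter of each other: a 1.7-fold higher number from compound 1 to compound 2 (0.23 log units; within the scatter). Compound 3, with thiophen-2-yl in place of phenyl on the carbonyl carbon, is the one that differs beyond the scatter: a 3.9-fold lower number from compound 1 to compound 3 (0.59 log units; beyond the scatter). The same exchange starting from the amino-bearing compound reads a 6.7-fold lower number from compound 2 to compound 3 (0.83 log units; beyond the scatter).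

Compound 4, `COc1ccc(-c2cc3ccccc3nc2/C=C/C(=O)c2ccccn2)cc1`, is not yet measured. It differs from compound 1 in one place: pyridin-2-yl in place of phenyl on a carbonyl carbon. The step that bears most on it is a 3.9-fold lower number from compound 1 to compound 3 (0.59 log units; beyond the scatter), where the phenyl on the carbonyl carbon likewise gave way to a ring with one hetero atom. Within the data shown here, with only one such exchange to go on, a modest step toward a lower number in this assay is expected, though a result within the scatter would not surprise. Compound 4 is therefore estimated at 2500 nM, within 900 nM to 7000 nM, an expected step of a 1.6-fold lower number from compound 1 to compound 4 (0.21 log units; within the scatter).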

Compound 4, half-maximal inhibitory concentration: 810 nM
Beside the measured number, compound 4's estimate is 3.1-fold (0.49 log units) above it, and the stated range ends above it.
By their numbers in this assay, from the lowest: compounds 4 and 3 (each within the scatter of the next); then compounds 1 and 2 (each within the scatter of the next).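

Exchanging the phenyl on the carbonyl carbon for pyridin-2-yl in this assay gives a 5.0-fold lower number from compound 1 to compound 4 (0.70 log units; beyond the scatter), so thiophen-2-yl is no longer the only ring with a hetero atom at this place that goes with a lower number than phenyl. Set against thiophen-2-yl, pyridin-2-yl gives a 1.3-fold lower number from compound 3 to compound 4 (0.10 log units; within the scatter), which means that these two rings cannot be told apart in this assay, even though they differ in the ring itself and in the hetero atom it carries. Pyridin-2-yl in place of 4-aminophenyl gives an 8.5-fold lower number from compound 2 to compound 4 (0.93 log units; beyond the scatter), and this shows that the same ring also reads beyond the scatter against the amino-bearing compound, as thiophen-2-yl did.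

Still open, as far as these compounds go, is whether the place of the ring nitrogen matters, and whether pyridin-3-yl, pyridin-4-yl or furan-2-yl on the carbonyl carbon would read like pyridin-2-yl. No measurement among those shown offers an explanation for the lower numbers at this position.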